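This account rests on a few compounds, and the source may have more. Where it says the series, first, only, none or still open, it means among the compounds named here.

In a functional assay on HGC-27 cells (Homo sapiens) for inhibition, read by MTT assay, with a stated time of 72 h (a lower number here means a stronger inhibitor, a higher number a weaker inhibitor), compound 1 `Cc1cc(N2CC[C@@H](C)[C@@H](N(C)c3ncnc4[nH]ccc34)C2)n2ncnc2n1` gives 11300 nM. Compound 2 `Cc1cc(N2CC[C@@H](C)[C@@H](N(C)c3ncnc4[nH]ccc34)C2)n2nc(SCCc3ccccc3)nc2n1` gives 11800 nM. Compound 3 `Cc1cc(N2CC[C@@H](C)[C@@H](N(C)c3ncnc4[nH]ccc34)C2)n2nc(SCc3ccc(F)c(Cl)c3)nc2n1` reads > 100000 nM, which is a limit and not a number. Compound 4 `C#CSc1nc2nc(C)cc(N3CC[C@@H](C)[C@@H](N(C)c4ncnc5[nH]ccc45)C3)n2n1` has ethynyl in place of 3-chloro-4-fluorobenzyl on a sulfur. Phenethylsulfanyl left the number unmoved, with a 1.0-fold higher number from compound 1 to compound 2 (0.02 log units; within the scatter). (3-Chloro-4-fluorobenzyl)sulfanyl raised it, with an at least 8.8-fold higher number from compound 1 to compound 3 (0.94 log units; beyond the scatter), and the comparison of these two groups shows an at least 8.4-fold higher number from compound 2 to compound 3 (0.92 log units; beyond the scatter). Only the group that compound 4 gives up has moved the number beyond the scatter, so a lower number is expected in this assay, near the level of compound 1 at 11300 nM. The expected step is an at least 6.6-fold lower number from compound 3 to compound 4 (0.82 log units; beyond the scatter). Compound 4 is estimated at 15000 nM, within a range of 4000 nM to 60000 nM.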

Compound 4, half-maximal inhibitory concentration: 35100 nM
Compound 4: middle estimate off by 2.3-fold (0.37 log units), on the low side; low and high end bracket the measured number.
By their numbers in this assay, from the lowest: compounds 1 and 2 (each within the scatter of the next); then compound 4. At a limit, above all of these: compound 3.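

In this assay, a group on this aromatic carbon can raise the number even when it is small: ethynylsulfanyl in place of hydrogen gives a 3.1-fold higher number from compound 1 to compound 4 (0.49 log units; beyond the scatter), and ethynyl in place of phenethyl gives a 3.0-fold higher number from compound 2 to compound 4 (0.47 log units; beyond the scatter). Shrinking the group on the sulfur lowers the number, with an at least 2.8-fold lower number from compound 3 to compound 4 (0.45 log units; beyond the scatter), but does not return it to the level of compound 1 or compound 2. That step has only one measured end, as compound 3 stands at a limit and not at a number: the limit of > 100000 nM in this assay, at which 1 of the 4 values shown sits.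

Still open, on these data alone, is how a methyl or an amine-bearing chain on the sulfur would read. Also open, as far as these compounds go, is whether the sulfur itself matters, which an oxygen in its place would test.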